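Ring Size on the Amine: Cyclopentyl to Cyclohexyl

The source may report more compounds than this note shows. Statements on the series, on what has been measured and on what is new or still open speak of the compounds shown alone.

Measured compounds: compound 1 `CC(C)(C)CN1CCCN(CCn2ccc3ccc(Br)cc32)CC1` gives 70% in an assay on HEK293 cells for binding affinity to 5-hydroxytryptamine receptor 7 (Homo sapiens), read by radioligand binding, tested at 1 uM; on this read-out lower numbers stand for less inhibition and higher numbers for more inhibition at the one concentration tested (going by the name of the read-out); compound 2 `Brc1ccc2ccn(CCN3CCCN(CC4CC4)CC3)c2c1` gives 95%; compound 3 `Brc1ccc2ccn(CCN3CCCN(C4CCCC4)CC3)c2c1` gives 98%.

Compound 3 and compound 2 lie within the scatter of each other, while compound 1 sits well below both. Compound 4 `Brc1ccc2ccn(CCN3CCCN(C4CCCCC4)CC3)c2c1` differs from compound 3 by cyclohexyl in place of cyclopentyl on an amine nitrogen in a ring. The relevant steps are a number 28 percentage points higher from compound 1 to compound 3 (beyond the scatter) and a number 3 percentage points higher from compound 2 to compound 3 (within the scatter): moving from an open chain to a ring on this nitrogen raised inhibition, but swapping one ring for another of similar kind did not. Compound 3 is already near the top of the scale, so compound 4 is expected to stay near it, with a number 2 percentage points lower from compound 3 to compound 4 (within the scatter). The estimate for compound 4 is 96%, between 88% and 100%.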

Compound 4, a percentage reported as inhibition, at one concentration (the size of the read-out at that concentration, not a potency): 96%
The estimate for compound 4 equals the measured number at the digits printed; measured number inside the range.
By their numbers in this assay, from the lowest: compound 1; then compounds 2, 4 and 3 (each within the scatter of the next).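

Cyclohexyl and cyclopentyl on this amine nitrogen are not told apart in this assay (a number 2 percentage points lower from compound 3 to compound 4 (within the scatter)), so the added ring carbon brings no visible change. Cyclohexyl also matches cyclopropylmethyl (a number 1 percentage points higher from compound 2 to compound 4 (within the scatter)), which leaves compounds 2, 3 and 4 together, while neopentyl remains apart (a number 26 percentage points higher from compound 1 to compound 4 (beyond the scatter)). No supporting data explain why neopentyl differs. Going by these compounds, whether this level holds with a larger cycloheptyl ring or a ring containing nitrogen, such as piperidinyl, remains open. On these data alone, an open n-butyl chain on this nitrogen is equally open.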